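Thioether variation in a nucleoside series: methyl to benzyl

A few compounds are considered here, and "the series" means these few. Any claim that something is new, unique, unknown or untested is made for them only; others in the source may bear on it.

Measured compounds:
- compound 1 `Cc1nsc2[nH]cnc12`: in a functional assay on L1210 cells (Mus musculus) for antiproliferative activity (a higher number here means a weaker inhibitor, a lower number a stronger inhibitor), compound 1 gives 17000 nM.
- compound 2 `CSc1nc2c(C)nsc2n1[C@H]1C[C@H](O)[C@@H](CO)O1`: compound 2 gives only a limit of the assay, > 100000 nM.
- compound 3 `CSc1nc2cnsc2n1[C@H]1C[C@H](O)[C@@H](CO)O1`: compound 3 gives only a limit of the assay, > 100000 nM.

Compound 3 stands at the limit, not at a number; it is one of the two values at the limit of > 100000 nM in this assay, at which 2 of the 3 values shown sit. Going by the values given here, the only measured step, a step that the two limits leave unreadable from compound 2 to compound 3, is therefore not readable as a size, and the value of compound 1 belongs to a compound without the sugar part, so it gives no step that bears on the change considered next.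

Compound 4 `OC[C@H]1O[C@@H](n2c(SCc3ccccc3)nc3cnsc32)C[C@@H]1O` differs from compound 3 by phenyl in place of hydrogen on a saturated chain carbon bound to a sulfur. Among the compounds with values here, no measured step touches this change; nothing among the measurements shows where a benzylsulfanyl group in place of a methylsulfanyl group would lead. With compound 3 at the limit, the working expectation is that compound 4 also sits at or near the limit. The estimated step, a number no higher from compound 3 to compound 4 (the limit leaves the size open), is taken as none beyond the scatter. For compound 4 the estimate is 100000 nM, with a range from 30000 nM to 300000 nM.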

Compound 4, half-maximal inhibitory concentration: 8000 nM
Compound 4: the middle estimate sits 13-fold (1.10 log units) above what was measured; measured number below the stated range.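

Benzylsulfanyl in place of methylsulfanyl gives, in this assay, an at least 12-fold lower number from compound 3 to compound 4 (1.09 log units; beyond the scatter), the first readable step among the compounds carrying the sugar part; the earlier step between such compounds cannot be read. This shows that the group on the sulfur can shift the antiproliferative read-out, which compounds 2 and 3 could not show. Compound 3 gives only a limit of the assay, > 100000 nM, so the step is a bound and not a full size: the limit of > 100000 nM in this assay, at which 2 of the 4 values shown sit.

From the compounds shown here alone, what an ethylsulfanyl or cyclohexylmethylsulfanyl group would give at this sulfur stays open, so the step cannot yet be assigned to the phenyl ring rather than to a longer chain. Also open, going by these compounds, are the effect of a fluorine or methoxy group on that phenyl ring and whether the step carries over to compound 2, with its methyl on an aromatic carbon.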